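Methyl for fluoro on the benzyl group of compound 3

This account rests on a few compounds, and the source may have more. Where it says the series, first, only, none or still open, it means among the compounds named here.

Compound 1 `C#CCOc1cc(O)c2c(c1)O[C@H](c1ccc(OC)c(O)c1)C/C2=N\O`: 19100 nM
Compound 2 `COc1ccc([C@@H]2C/C(=N\O)c3c(O)cc(OCc4cn(Cc5ccccc5F)nn4)cc3O2)cc1O`: 5710 nM
Compound 3 `COc1ccc([C@@H]2CC(=O)c3c(O)cc(OCc4cn(Cc5ccccc5F)nn4)cc3O2)cc1O`: 7320 nM

In a functional assay on RAW264.7 cells (Mus musculus) for inhibition, read by Griess assay, with stated times of 2 h and 24 h (on this read-out lower numbers stand for stronger inhibition and higher numbers for weaker inhibition), compound 3 gives 7320 nM, the second highest of the three numbers. Its nearest neighbour is compound 2, whose 5710 nM lies within the scatter of it; compound 1, with 19100 nM, shows a higher number that lies beyond the scatter. Compound 4 `COc1ccc([C@@H]2CC(=O)c3c(O)cc(OCc4cn(Cc5ccccc5C)nn4)cc3O2)cc1O` differs from compound 3 in one place: methyl in place of fluoro on an aromatic carbon. Within the data shown here, no step between measured compounds here involves that position, so the data give no direct guide. The change is expected to leave the number where it stands, with a 1.0-fold lower number from compound 3 to compound 4 (0.02 log units; within the scatter) as an estimate inside the scatter. Compound 4 is therefore estimated at 7000 nM, within a range from 3000 nM to 16000 nM.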

Compound 4, half-maximal inhibitory concentration: 13100 nM
For compound 4 the middle estimate is 1.9-fold (0.27 log units) below the measured one, and the stated range covers the measured number.
By their numbers in this assay, from the lowest: compounds 2, 3, 4 and 1 (each within the scatter of the next, the first and the last beyond it).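

In this assay, among these compounds, the change from 2-fluorobenzyl to 2-methylbenzyl gives a 1.8-fold higher number from compound 3 to compound 4 (0.25 log units; within the scatter), the first step that can be read at this position. On this one pair, methyl and fluoro on this aromatic carbon cannot be told apart beyond the usual scatter. Nothing at hand offers an explanation for the step. From the compounds shown here alone, it remains open whether an amine or a carboxylic acid on this aromatic carbon would move the number beyond the scatter. Going by these compounds, it is also open whether 2-methylbenzyl would give a similar step on the core of compound 2.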